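Replacing a urea cap with a sulfonamide on a shared core

This account rests on a few compounds, and the source may have more. Where it says the series, first, only, none or still open, it means among the compounds named here.

The measured compounds and their values in an assay on isolated protein for displacement of a labelled ligand from 5-hydroxytryptamine receptor 6 (Homo sapiens) (a higher number here means a weaker inhibitor, a lower number a stronger inhibitor), are:
compound 1, `O=C1CN=C(NC[C@@H]2CCCc3cc(S(=O)(=O)c4cccc(F)c4)ccc32)N1`, 0.1 nM;
compound 2, `O=S(=O)(c1cccc(F)c1)c1ccc2c(c1)CCC[C@H]2CNCCO`, 0.126 nM;
compound 3, `CNC(=O)NC[C@@H]1CCCc2cc(S(=O)(=O)c3cccc(F)c3)ccc21`, 0.398 nM.

Compound 3 has the highest number of the three. Its nearest neighbour is compound 2, with a 3.2-fold higher number from compound 2 to compound 3 (0.50 log units; beyond the scatter), and the furthest is compound 1, with a 4.0-fold higher number from compound 1 to compound 3 (0.60 log units; beyond the scatter). Both of those steps exchange the group on the amine nitrogen of the shared core, and both are modest.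

Compound 4, `CS(=O)(=O)NC[C@@H]1CCCc2cc(S(=O)(=O)c3cccc(F)c3)ccc21`, differs from compound 3 only at that same nitrogen: methylsulfonyl in place of methylcarbamoyl on an amine nitrogen. Among the compounds with values here, no measured step exchanges a methylcarbamoyl for a methylsulfonyl, so the two earlier steps bear on it only loosely, showing that changes at this position so far moved the number by modest amounts in either direction. Compound 4 is therefore expected to stay close to compound 3, with a step of a 1.5-fold higher number from compound 3 to compound 4 (0.18 log units; within the scatter) in this assay. The estimate for compound 4 is 0.6 nM, within a range from 0.2 nM to 2 nM.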

Compound 4, inhibition constant: 0.2 nM
Compound 4: the middle estimate sits 3.0-fold (0.48 log units) above what was measured, within the range that was stated.
By their numbers in this assay, from the lowest: compounds 1, 2, 4 and 3 (each within the scatter of the next, the first and the last beyond it).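

In this assay, within the data shown here, the exchange of methylcarbamoyl for methylsulfonyl on the amine nitrogen stays within the scatter (a 2.0-fold lower number from compound 3 to compound 4 (0.30 log units; within the scatter)), so removing the one hydrogen-bond donor counted in methylcarbamoyl brings no step that can be read at this position. Compound 4 also lies within the scatter of the 2-hydroxyethyl group of compound 2 (a 1.6-fold higher number from compound 2 to compound 4 (0.20 log units; within the scatter)) and of the ring-bearing group of compound 1 (a 2.0-fold higher number from compound 1 to compound 4 (0.30 log units; within the scatter)), whereas compound 3 lies beyond the scatter of both. The methylsulfonyl group therefore adds a sulfur-centred group to those seen on this nitrogen, and none of its three new steps can be read as a change.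

Going by these compounds, whether a longer chain such as ethylsulfonyl, an aromatic group such as phenylsulfonyl or the unsubstituted amine would keep the number in this range remains open. Nothing shown here accounts for these steps.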